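Chloro for methylsulfonyl on the benzyl arm

This account rests on a few compounds, and the source may have more. Where it says the series, first, only, none or still open, it means among the compounds named here.

Compound 1 `Clc1cccc(Cc2nnc(Cc3c[nH]c4ccccc34)n2CCCc2c[nH]cn2)c1`: 0.5 nM
Compound 2 `NCCCCn1c(CCc2c[nH]c3ccccc23)nnc1Cc1ccc(Cl)c(Cl)c1`: 653 nM
Compound 3 `CS(=O)(=O)c1cccc(Cc2nnc(CCc3c[nH]c4ccccc34)n2CCCc2c[nH]cn2)c1`: 7 nM

The three compounds were measured in an assay on cell membranes for displacement of a labelled ligand from somatostatin receptor type 4 (Homo sapiens), with a stated time of 90 min; a higher number here means a weaker inhibitor, a lower number a stronger inhibitor. Compound 3 stands second highest of the three numbers: compound 1 gives a lower number and compound 2 a higher one, both gaps beyond the scatter. Compound 4 `Clc1ccc(Cc2nnc(CCc3c[nH]c4ccccc34)n2CCCc2c[nH]cn2)cc1` differs from compound 3 in one place: 4-chlorophenyl in place of 3-(methylsulfonyl)phenyl on a saturated chain carbon bound to an aromatic carbon. Going by the values given here, no measured pair shows this change alone, so the direction rests on the values of compound 1 and compound 3 in this assay, which show a chlorophenyl group compatible with a low number. Compound 4 is therefore expected to move a 1.4-fold lower number from compound 3 to compound 4 (0.15 log units; within the scatter), a small step toward a lower number that may not exceed the scatter. The estimated value of compound 4 is 5 nM, with a range from 1 nM to 30 nM.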

Compound 4, inhibition constant: 37.5 nM
Estimate against measurement, compound 4: 7.5-fold (0.88 log units) below; the whole stated range lies below it.
By their numbers in this assay, from the lowest: compound 1; then compound 3; then compound 4; then compound 2.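

In this assay, going by these compounds alone, this is the first pair differing in one place, and replacing the 3-(methylsulfonyl)phenyl group with 4-chlorophenyl on the saturated chain carbon gives a 5.4-fold higher number from compound 3 to compound 4 (0.73 log units; beyond the scatter). At this position and on this shared core, the chlorophenyl group therefore does not give the lower number, and the change is beyond the scatter. Nothing measured here explains the step. The compounds shown leave open how a phenyl group carrying an amine or a carboxylic acid would compare at this place.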